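Aryl swap on the ring nitrogen: cytotoxicity working notes

A few compounds are considered here, and "the series" means these few. Any claim that something is new, unique, unknown or untested is made for them only; others in the source may bear on it.

Measured so far in an ADME assay on HT-29 cells (Homo sapiens) for cytotoxicity, read by MTT assay, with a stated time of 72 h; a higher number here means a weaker inhibitor, a lower number a stronger inhibitor:
- compound 1 `C=CC(=O)Nc1cc(Nc2ncc3ncn(-c4ccc(C)cc4)c3n2)c(OC)cc1N(C)CCN(C)C`: 9230 nM
- compound 2 `C=CC(=O)Nc1cc(Nc2ncc3ncn(-c4ccc(C(C)C)cc4)c3n2)c(OC)cc1N(C)CCN(C)C`: 15300 nM
- compound 3 `C=CC(=O)Nc1cc(Nc2ncc3ncn(-c4ccc(I)cc4)c3n2)c(OC)cc1N(C)CCN(C)C`: 9520 nM

Compound 3 holds the second-highest number of the three measured compounds. Its nearest neighbour is compound 1, as a 1.0-fold higher number from compound 1 to compound 3 (0.01 log units; within the scatter) shows, and its furthest is compound 2, as a 1.6-fold lower number from compound 2 to compound 3 (0.21 log units; within the scatter) shows; both gaps sit within the scatter, so the three compounds are not separated by this assay. The remaining step, a 1.7-fold higher number from compound 1 to compound 2 (0.22 log units; within the scatter), is likewise within the scatter.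

Compound 4 `C=CC(=O)Nc1cc(Nc2ncc3ncn(-c4ccccc4F)c3n2)c(OC)cc1N(C)CCN(C)C` is the next member. The change from compound 3 is 2-fluorophenyl in place of 4-iodophenyl on an aromatic nitrogen. Among the measured compounds shown here, every measured step so far is a change of the substituent on that same aryl group, and none of them moved this assay beyond the scatter. The step to compound 4 changes both the substituent and its position on the aryl group, which the measured steps do not cover directly. On the evidence at hand, no step beyond the scatter is expected: for compound 4 the expected value is 9500 nM, with a range of 4000 nM to 23000 nM, which means an expected step of a 1.0-fold lower number from compound 3 to compound 4 (0.00 log units; within the scatter).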

Compound 4, half-maximal inhibitory concentration: 9750 nM
The estimate for compound 4 lay 1.0-fold (0.01 log units) below the measured number; the range from low to high includes it.
By their numbers in this assay, from the lowest: compounds 1, 3, 4 and 2 (each within the scatter of the next).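

In this assay, 2-fluorophenyl on the aromatic nitrogen stays within the scatter of 4-iodophenyl (a 1.0-fold higher number from compound 3 to compound 4 (0.01 log units; within the scatter)), of 4-isopropylphenyl (a 1.6-fold lower number from compound 2 to compound 4 (0.20 log units; within the scatter)) and of 4-methylphenyl (a 1.1-fold higher number from compound 1 to compound 4 (0.02 log units; within the scatter)). The earlier steps shown here changed only the substituent, whereas this one changes both the substituent and its place on the aryl group, and this assay still does not separate the four compounds. No available evidence bears on the reason for this result.

Going by these compounds, whether the same holds for an aryl group carrying an amine or a carboxylic acid, or for a longer alkyl chain in place of the aryl group on that nitrogen, remains open. The compounds shown also share the rest of the core, so the response of this assay to changes elsewhere remains open too.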